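The source may hold more compounds than are shown below. What is called first, only, known or untested is meant among the compounds shown, and "the series" means these compounds.

Measured so far:
compound 1, `CCSc1nc2c(n1Cc1ccc(OC)cc1)C(=O)N(CC)C1=N[C@@H]3CCC[C@@H]3N12` — 4.67 in a physicochemical assay for lipophilicity, measured as octanol-water partition; on this read-out lower numbers stand for lower lipophilicity and higher numbers for higher lipophilicity
compound 2, `CCSc1nc2c(n1Cc1ccc(O)cc1)C(=O)N(CC)C1=N[C@@H]3CCC[C@@H]3N12` — 4.41
compound 3, `CCN1C(=O)c2c(nc(C(=O)NC)n2Cc2ccc(OC)c(Cl)c2)N2C1=N[C@@H]1CCC[C@@H]12` — 3.26

Compound 2 arises from compound 1 by hydrogen in place of methyl on an oxygen on an aromatic ring, and in this assay this gives a number 0.26 log units lower from compound 1 to compound 2 (within the scatter). Compound 3 has the lowest value of the three; the difference between its core and that of compound 1 is not broken down here. Compound 4, `CCN1C(=O)c2c(nc(C(=O)NC)n2Cc2ccc(O)c(Cl)c2)N2C1=N[C@@H]1CCC[C@@H]12`, arises from compound 3 by hydrogen in place of methyl on an oxygen on an aromatic ring, the same change as from compound 1 to compound 2, made at the same kind of place. The step from compound 3 to compound 4 is therefore expected to be small, resting on the step of a number 0.26 log units lower from compound 1 to compound 2 (within the scatter): an estimated a number 0.26 log units lower from compound 3 to compound 4 (within the scatter). In this assay compound 4 is expected to give about 3, between 2.6 and 3.4.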

Compound 4, partition coefficient: 3
Compound 4: the middle estimate sits on the measured number at the digits printed, and the stated range covers the measured number.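

In this assay, the change from methoxy to hydroxy gives a number 0.26 log units lower from compound 3 to compound 4 (within the scatter), and on the core of compound 1 it gives a number 0.26 log units lower from compound 1 to compound 2 (within the scatter), so on both cores shown the step stays within the usual scatter. Among the compounds shown here, this rests on only two pairs, and since neither step stands clear of the scatter, it does not establish a real shift, nor that the change would behave alike on other cores. Nothing measured here bears on why the step has this size.

The compounds shown leave open what a longer chain, such as propyl, would do on that oxygen. They also leave open whether an amine or a carboxylic acid in place of the hydroxy would give a comparable step on either core.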